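The source may hold more compounds than are shown below. What is called first, only, known or untested is meant among the compounds shown, and "the series" means these compounds.

In a functional assay on DU-145 cells (Homo sapiens) for inhibition, read by trypan blue exclusion, with a stated time of 96 h (a lower number here means a stronger inhibitor of growth, a higher number a weaker inhibitor of growth), compound 1 (`Cc1ccc(CS(=O)(=O)/C(=C/c2c[nH]c3ccccc23)C(=O)c2ccc(Cl)cc2)cc1`) gives 25000 nM and compound 2 (`Cc1ccc(CS(=O)(=O)/C(=C/c2sccc2C)C(=O)c2ccc(Cl)cc2)cc1`) gives 25000 nM, so compound 2 stands level with compound 1, its nearest neighbour in this small series. Going by the values given here, compound 3 (`Cc1ccc(CS(=O)(=O)/C(=C/c2cc(C)ccc2C)C(=O)c2ccc(Cl)cc2)cc1`) is the next case, and its change falls at the same place as the one measured step: 2,5-dimethylphenyl in place of 3-methylthiophen-2-yl on a double-bonded chain carbon bound to a double-bonded chain carbon. In words, this is 2,5-dimethylphenyl in place of 3-methylthiophen-2-yl on a double-bonded chain carbon bound to a double-bonded chain carbon.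

Among the compounds with values here, the only evidence at this place is no change at the digits printed from compound 1 to compound 2 (within the scatter), an exchange of one aromatic group for another that left the reading within the scatter. Within the data shown here, that is a single step between two compounds, and no compound with a six-membered aromatic ring of carbon only at this place has been measured yet, so the support is thin. No step beyond the scatter is therefore expected in this assay, and no direction is favoured with any confidence. The expected step is a 1.3-fold lower number from compound 2 to compound 3 (0.10 log units; within the scatter). For compound 3 the estimated value is 20000 nM, with an expected range of 6000 nM to 40000 nM.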

Compound 3, concentration for 50% growth inhibition: 1000 nM
Beside the measured number, compound 3's estimate is 20-fold (1.30 log units) above it, outside the stated range (below it).
By their numbers in this assay, from the lowest: compound 3; then compounds 1 and 2 (each within the scatter of the next).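

In this assay, 2,5-dimethylphenyl in place of 3-methylthiophen-2-yl on a double-bonded chain carbon bound to a double-bonded chain carbon gives a 25-fold lower number from compound 2 to compound 3 (1.40 log units; beyond the scatter), and the same group in place of 1H-indol-3-yl gives a 25-fold lower number from compound 1 to compound 3 (1.40 log units; beyond the scatter). The position therefore does respond to the choice of aromatic group, which the earlier exchange, no change at the digits printed from compound 1 to compound 2 (within the scatter), gave no sign of, and among the three compounds only the 2,5-dimethylphenyl group stands apart from the other two. No measurement in hand accounts for this difference.

The step from 3-methylthiophen-2-yl changes ring size, hetero atom content and heavy-atom count together, so the compounds shown leave open whether the lower number belongs to the six-membered aromatic ring of carbon only or to its two methyl groups, a question that an unsubstituted phenyl would help to settle. They also leave open whether methoxy groups could stand in place of the two methyl groups, and whether a pyridyl ring would read with the 2,5-dimethylphenyl compound or with the other two.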